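Swapping a saturated ring for an aromatic one on the amine

The compounds below may be only part of what the source reports. "The series", "measured", "known", "first", "only" and "open" are said of these compounds alone.

Measured so far:
compound 1 `CCCCNc1nc(C(F)(F)F)ccc1CNC(=O)C(C)c1ccc(NS(C)(=O)=O)c(F)c1` 9.1 nM
compound 2 `CC(C(=O)NCc1ccc(C(F)(F)F)nc1NC1CCCCC1)c1ccc(NS(C)(=O)=O)c(F)c1` 20.4 nM
compound 3 `CC(C(=O)NCc1ccc(C(F)(F)F)nc1NCC1CCN(C(=O)OC(C)(C)C)CC1)c1ccc(NS(C)(=O)=O)c(F)c1` 19.3 nM

In a functional assay on CHO-K1 cells for antagonist activity at transient receptor potential cation channel subfamily V member 1 (Homo sapiens), read by FLIPR (on this read-out lower numbers stand for stronger inhibition and higher numbers for weaker inhibition), compound 2 gives the highest number of the three, but compound 3 sits within the scatter of it, so the two cannot be told apart; only compound 1 is clearly separated, and the step of a 2.2-fold higher number from compound 1 to compound 2 (0.35 log units; beyond the scatter) shows that separation. Compound 4 `CC(C(=O)NCc1ccc(C(F)(F)F)nc1Nc1ccccc1)c1ccc(NS(C)(=O)=O)c(F)c1` differs from compound 2 by phenyl in place of cyclohexyl on a nitrogen on an aromatic ring. Going by the values given here, no measured step covers this swap of a six-membered non-aromatic ring for an aromatic one; the only step available, from butyl to cyclohexyl, was modest. A similarly modest change in either direction is therefore expected, with a slight lean toward a higher number, so for compound 4 the estimate is 30 nM (range 10 nM to 100 nM), a step of a 1.5-fold higher number from compound 2 to compound 4 (0.17 log units; within the scatter).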

Compound 4, inhibition constant: 59.6 nM
Compound 4: the middle estimate sits 2.0-fold (0.30 log units) below what was measured; low and high end bracket the measured number.
By their numbers in this assay, from the lowest: compound 1; then compounds 3 and 2 (each within the scatter of the next); then compound 4.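

In this assay, the nitrogen position distinguishes between two six-membered rings of equal heavy-atom count: cyclohexyl to phenyl gives a 2.9-fold higher number from compound 2 to compound 4 (0.47 log units; beyond the scatter) and so weakens inhibition. Replacing butyl with phenyl gives a 6.5-fold higher number from compound 1 to compound 4 (0.82 log units; beyond the scatter) in the same direction, so phenyl is clearly poorer than either group in this pair of comparisons. Nothing measured here explains this difference.

Still open, on these data alone, is whether a methoxy group on the phenyl would restore inhibition. Also open, as far as these compounds go, is how a chain longer than butyl would compare.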